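The source may hold more compounds than are shown below. What is called first, only, known or untested is meant among the compounds shown, and "the series" means these compounds.

Series notes. Each compound carries the shared core with a varied group on a nitrogen on an aromatic ring. Compound 1 `O=C(NCc1ccc(F)cc1)c1nc(Br)c2cccnc2c1NCc1ccccc1` in a functional assay on MDA-MB-435 cells (Homo sapiens) for cytotoxicity, read by MTT assay, with a stated time of 72 h (a lower number here means a stronger inhibitor, a higher number a weaker inhibitor), gives only a limit, > 20000 nM, not a number. Compound 2 `Nc1ccc(Nc2c(C(=O)NCc3ccc(F)cc3)nc(Br)c3cccnc23)cc1` gives 7000 nM in this assay, and compound 3 `N[C@H]1CC[C@H](Nc2c(C(=O)NCc3ccc(F)cc3)nc(Br)c3cccnc23)CC1` gives 6000 nM. Compound 3 and compound 2 stand within the scatter of each other, a 1.2-fold lower number from compound 2 to compound 3 (0.07 log units; within the scatter). Both are set apart from compound 1: an at least 2.8-fold lower number from compound 1 to compound 2 (0.45 log units; beyond the scatter) and an at least 3.3-fold lower number from compound 1 to compound 3 (0.52 log units; beyond the scatter), each read against the limit (the limit of > 20000 nM in this assay, at which 1 of the 3 values shown sits). Compound 4 `O=C(NCc1ccc(F)cc1)c1nc(Br)c2cccnc2c1NCc1ccc(F)cc1` is to be measured in this assay; the change is 4-fluorobenzyl in place of 4-aminocyclohexyl on a nitrogen on an aromatic ring. It removes the 4-aminocyclohexyl that, in the step of an at least 3.3-fold lower number from compound 1 to compound 3 (0.52 log units; beyond the scatter), came with the lower number, and brings in a 4-fluorobenzyl that resembles the benzyl of compound 1. The expected step is a return toward the limit seen for compound 1, a 3.3-fold higher number from compound 3 to compound 4 (0.52 log units; beyond the scatter). Compound 4 is expected to give 20000 nM, within 8000 nM to 60000 nM, with a real chance that only a limit is reported.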

Compound 4, half-maximal inhibitory concentration: > 20000 nM
Compound 4: no number, only a limit; the forecaster's own chance of this, stated with the estimate: 60%; the middle value sits exactly at the limit.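

Among the groups on this nitrogen, the 4-fluorobenzyl falls with benzyl and not with 4-aminocyclohexyl or 4-aminophenyl in this assay: an at least 3.3-fold higher number from compound 3 to compound 4 (0.52 log units; beyond the scatter), and an at least 2.8-fold higher number from compound 2 to compound 4 (0.45 log units; beyond the scatter). The two groups carrying an amine give numbers, while the two benzyl groups without one give only limits: the limit of > 20000 nM in this assay, at which 2 of the 4 values shown sit. The step between the two benzyl compounds cannot be read, since neither has a number, so the effect of the added fluoro remains unresolved.

The amine and the group that carries it change together here, so a benzyl carrying an amine, or a plain cyclohexyl on this nitrogen, would be needed to separate the two. Going by these compounds, whether a longer chain ending in an amine, or a carboxylic acid in place of the amine, would keep the numbers of compound 2 and compound 3 also stays open.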